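Naphthalen-2-yl replacing 4-methoxyphenyl on the benzyl-type arm

A few compounds are considered here, and "the series" means these few. Any claim that something is new, unique, unknown or untested is made for them only; others in the source may bear on it.

Compound 3 `COc1ccc(Cn2cc(CSc3nnc(-c4ccccc4)c(-c4ccccc4)n3)nn2)cc1` gives 27500 nM in a functional assay on PC-3 cells (Homo sapiens) for antiproliferative activity, read by MTT assay, with a stated time of 48 h; a higher number here means a weaker inhibitor, a lower number a stronger inhibitor; compound 1 `Clc1ccc(Cn2cc(CSc3nnc(-c4ccccc4)c(-c4ccccc4)n3)nn2)cc1` gives 14700 nM and compound 2 `Brc1ccc(Cn2cc(CSc3nnc(-c4ccccc4)c(-c4ccccc4)n3)nn2)cc1` gives 22000 nM. Compound 3 carries the largest of the three numbers, but a 1.9-fold higher number from compound 1 to compound 3 (0.27 log units; within the scatter) and a 1.3-fold higher number from compound 2 to compound 3 (0.10 log units; within the scatter) both lie within the scatter, as does a 1.5-fold higher number from compound 1 to compound 2 (0.18 log units; within the scatter). Compound 4 `c1ccc(-c2nnc(SCc3cn(Cc4ccc5ccccc5c4)nn3)nc2-c2ccccc2)cc1` differs from compound 3 by naphthalen-2-yl in place of 4-methoxyphenyl on a saturated chain carbon bound to an aromatic nitrogen. Among the compounds with values here, none of the measured steps exchanges a whole aryl ring; they only show that varying the group on that ring leaves this assay essentially unchanged. A step near the scatter is therefore expected, a 1.4-fold lower number from compound 3 to compound 4 (0.14 log units; within the scatter), with no firm direction. Compound 4 is estimated at 20000 nM, between 7000 nM and 60000 nM.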

Compound 4, half-maximal inhibitory concentration: > 100000 nM
Compound 4: only a limit was reported (the forecaster's own chance of this, stated with the estimate: 10%); middle value at least 5.0-fold (0.69 log units) away from the limit.
By their numbers in this assay, from the lowest: compounds 1, 2 and 3 (each within the scatter of the next). At a limit, above all of these: compound 4.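

The result for compound 4 is a limit, not a number: the limit of > 100000 nM in this assay, at which 1 of the 4 values shown sits. With naphthalen-2-yl on a saturated chain carbon bound to an aromatic nitrogen, the series gives an at least 3.6-fold higher number from compound 3 to compound 4 (0.56 log units; beyond the scatter), an at least 4.5-fold higher number from compound 2 to compound 4 (0.65 log units; beyond the scatter) and an at least 6.8-fold higher number from compound 1 to compound 4 (0.83 log units; beyond the scatter). Exchanging chloro, bromo and methoxy on the phenyl ring stayed within the scatter, so this position responds to a change of the whole aryl group, at least for this one.

As far as these compounds go, the true size of the loss stays open. So does the effect of other arms here, such as an unsubstituted phenyl, a pyridin-3-yl ring or a carboxylic acid on the ring.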